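From naphthalen-1-yl to propyl on a sulfonyl sulfur

A few compounds are considered here, and "the series" means these few. Any claim that something is new, unique, unknown or untested is made for them only; others in the source may bear on it.

Three measured compounds share one core and differ only in the group on the sulfonyl sulfur: compound 1 `Cc1ccc(S(=O)(=O)n2cc(/C=C/C(=O)c3ccncc3)c3ccccc32)cc1`, compound 2 `O=C(/C=C/c1cn(S(=O)(=O)c2cccc([N+](=O)[O-])c2)c2ccccc12)c1ccncc1` and compound 3 `O=C(/C=C/c1cn(S(=O)(=O)c2cccc3ccccc23)c2ccccc12)c1ccncc1`. In a functional assay on HepG2 cells (Homo sapiens) for antiproliferative activity, read by MTT assay, with a stated time of 48 h (a higher number here means a weaker inhibitor, a lower number a stronger inhibitor), compound 1 gives 44800 nM, compound 2 gives 42600 nM and compound 3 gives 62900 nM. Compound 3 therefore stands level with the other two, and the third comparison, a 1.1-fold lower number from compound 1 to compound 2 (0.02 log units; within the scatter), tells the same story.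

Compound 4 `CCCS(=O)(=O)n1cc(/C=C/C(=O)c2ccncc2)c2ccccc21` brings a larger change, with propyl in place of naphthalen-1-yl on a sulfonyl sulfur. Going by the values given here, two measured steps bear on it directly. They also replace the group that compound 3 carries: a 1.4-fold higher number from compound 1 to compound 3 (0.15 log units; within the scatter) and a 1.5-fold higher number from compound 2 to compound 3 (0.17 log units; within the scatter). Both are small, yet each swaps one ring-bearing group for another. Among the compounds with values here, no measured compound has a group without a ring at this place, so these steps are only an indirect guide. Even so, no step beyond the scatter is expected in this assay, though with real uncertainty. The expected change is a 1.3-fold lower number from compound 3 to compound 4 (0.10 log units; within the scatter). For compound 4 the estimated value is 50000 nM, with an expected range of 22000 nM to 100000 nM.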

Compound 4, half-maximal inhibitory concentration: 46200 nM
Compound 4: middle estimate off by 1.1-fold (0.03 log units), on the high side, and the stated range covers the measured number.
By their numbers in this assay, from the lowest: compounds 2, 1, 4 and 3 (each within the scatter of the next).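

Going by these compounds alone, compound 4 is the first compound here with no ring on the sulfonyl sulfur, and in this assay the three new steps all lie within the scatter: (a 1.4-fold lower number from compound 3 to compound 4 (0.13 log units; within the scatter)), (a 1.1-fold higher number from compound 2 to compound 4 (0.04 log units; within the scatter)) and (a 1.0-fold higher number from compound 1 to compound 4 (0.01 log units; within the scatter)). Even the exchange of naphthalen-1-yl, with 10 heavy atoms and 2 six-membered aromatic rings, for propyl, with 3 heavy atoms and no ring, leaves no readable mark, so among these four compounds neither an aromatic ring at this place nor the larger group separates one compound from another. No measurement shown here explains why the number stays level across these groups.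

The compounds shown leave open whether a group carrying an amine or a carboxylic acid on the sulfonyl sulfur, or a longer chain such as octyl, would also stay within the scatter of these four. They also leave open what happens when the shared core itself changes, since every compound here keeps it untouched and differs only in this one group.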